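This account rests on a few compounds, and the source may have more. Where it says the series, first, only, none or still open, it means among the compounds named here.

Compound 2, `O=C(N/N=C/c1ccc(Cl)c(Cl)c1)Nc1ccc(Oc2ccnc3[nH]ccc23)c(F)c1`, carries the same core as compound 1, `O=C(N/N=C/c1ccccc1)Nc1ccc(Oc2ccnc3[nH]ccc23)c(F)c1`, and differs from it only in the aromatic group on the carbon with a double bond to nitrogen. Among the compounds with values here, in a functional assay on HepG2 cells (Homo sapiens) for antiproliferative activity, read by MTT assay, with a stated time of 72 h (a lower number here means a stronger inhibitor, a higher number a weaker inhibitor), compound 1 gives 640 nM, whereas compound 2 gives 3700 nM, the higher of the two numbers measured so far. Within the data shown here, the single step between them, a 5.8-fold higher number from compound 1 to compound 2 (0.76 log units; beyond the scatter), is the only measured change and the only one that bears on what follows.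

Compound 3, `O=C(N/N=C/c1cc(Br)c(O)c(Br)c1)Nc1ccc(Oc2ccnc3[nH]ccc23)c(F)c1`, is not yet measured. The change from compound 2 to compound 3 is 3,5-dibromo-4-hydroxyphenyl in place of 3,4-dichlorophenyl on a carbon with a double bond to nitrogen. Among the measured compounds shown here, no measured pair exchanges one halogenated phenyl for another, nor introduces a hydroxyl on that ring, so the step from compound 2 to compound 3 has no direct precedent. For the measured compounds named here, the one step measured so far shows that varying this aromatic group moves the number by a modest margin, so a change of about that size in either direction would not be surprising, and no firm direction can be read from the data. The working expectation is therefore a step of roughly a 1.3-fold lower number from compound 2 to compound 3 (0.12 log units; within the scatter), with compound 3 estimated at 2800 nM in this assay, within a range from 700 nM to 11000 nM.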

Compound 3, half-maximal inhibitory concentration: 6520 nM
For compound 3 the middle estimate is 2.3-fold (0.37 log units) below the measured one; measured number inside the range.
By their numbers in this assay, from the lowest: compound 1; then compounds 2 and 3 (each within the scatter of the next).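

In this assay, 3,5-dibromo-4-hydroxyphenyl in place of 3,4-dichlorophenyl on the carbon with a double bond to nitrogen gives a 1.8-fold higher number from compound 2 to compound 3 (0.25 log units; within the scatter), so compound 2 and compound 3 cannot be told apart, although the entering group exchanges chlorine for bromine and adds a hydrogen-bond donor and a hydrogen-bond acceptor. Measured against the plain phenyl, the same group gives a 10-fold higher number from compound 1 to compound 3 (1.01 log units; beyond the scatter), which, read with a 5.8-fold higher number from compound 1 to compound 2 (0.76 log units; beyond the scatter), places both halogen-bearing rings beyond the scatter from compound 1, the compound with the lowest number of the three; at this position, the two substituted rings shown do not improve on plain phenyl, and no compound among the three goes against this. Nothing available on these compounds offers an explanation for these differences.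

The compounds shown leave open what the bromines and the hydroxyl each contribute alone, since compound 3 carries them together and their separate contributions could offset each other. Also open, going by these compounds, is whether a phenyl ring bearing an amine or a carboxylic acid would keep the number near compound 1 or move it as the halogen-bearing rings do.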